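The source may report more compounds than this note shows. Statements on the series, on what has been measured and on what is new or still open speak of the compounds shown alone.

Compound 3 `CCC(C(=O)N1CCN(c2cccc(C(F)(F)F)c2)CC1)N1C(=O)CCC1=O` gives the highest number among the three measured compounds in a functional assay on the whole organism (strain Swiss) with Mus musculus as the target, in the maximal electroshock model, with a stated time of 0.25 h, at a dose of 300 mg/kg by the intraperitoneal route (on this read-out lower numbers stand for a weaker effect and higher numbers for a stronger effect at the one dose given), where compound 3 reaches 75%. The next compound, compound 1 `CCC(C(=O)N1CCN(c2ccccc2Cl)CC1)N1C(=O)CCC1=O`, gives 50% in this assay, and compound 2 `CCC(C(=O)N1CCN(c2ccc(F)cc2)CC1)N1C(=O)CCC1=O` gives 0%, both values standing beyond the scatter below that of compound 3. Compound 4 `CCC(C(=O)N1CCN(c2cccc(C)c2)CC1)N1C(=O)CCC1=O` has not yet been measured; it differs from compound 3 in one place, (methyl in place of trifluoromethyl on an aromatic carbon), on an aromatic carbon of a six-membered aromatic ring of carbon only.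

Within the data shown here, only one measured step, a number 50 percentage points lower from compound 1 to compound 2 (beyond the scatter), bears on the question, and it swaps one aryl substituent pattern for another rather than exchanging methyl for trifluoromethyl; it shows that altering the group on this ring can shift the read-out by a large amount. Among the measured compounds shown here, no measured pair tells the direction of the present change. Compound 4 is therefore expected to fall in this assay, with the step of a number 25 percentage points lower from compound 3 to compound 4 (beyond the scatter) taken as the estimate. The estimate for compound 4 in this assay is 50%, within a range from 25% to 100%.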

Compound 4, a percentage reported as activity, at one dose (the size of the read-out at that dose, not a potency): 100%
Beside the measured number, compound 4's estimate is 50 percentage points below it; the range from low to high includes it.
By their numbers in this assay, from the lowest: compound 2; then compound 1; then compound 3; then compound 4.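

Among these compounds, the exchange of trifluoromethyl for methyl gives the first direct reading of this place on the aromatic ring: in this assay it produces a number 25 percentage points higher from compound 3 to compound 4 (beyond the scatter), so methyl stands above trifluoromethyl here at the one dose given. The 3-methylphenyl group also stands above the two other aryl groups, with a number 50 percentage points higher from compound 1 to compound 4 (beyond the scatter) and a number 100 percentage points higher from compound 2 to compound 4 (beyond the scatter), which puts compound 4 at the top of the four compounds, with all its steps beyond the scatter. Nothing measured here explains why the read-out moves with this change.

The compounds shown leave open how an ethyl group, a methoxy group or an amine would fare at this place. They also leave open how compound 4 would compare with compound 3 at lower doses or at other times.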